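The compounds below may be only part of what the source reports. "The series", "measured", "known", "first", "only" and "open" are said of these compounds alone.

Measured compounds in a functional assay on MCF7 cells (Homo sapiens) for cytotoxicity, read by MTT assay, with a stated time of 48 h; a higher number here means a weaker inhibitor, a lower number a stronger inhibitor:
- compound 1, `COc1ccc(CNC(=O)CSc2nc3ccc(NC(=O)c4ccccc4OC)cc3s2)cc1`: 9300 nM
- compound 2, `CC(=O)Nc1ccc2nc(SCC(=O)NCc3ccccc3)sc2c1`: 17600 nM
- compound 3, `CNC(=O)CSc1nc2ccc(NC(C)=O)cc2s1`: this value is a limit of the assay, not a number: > 100000 nM

Compound 1 gives the lowest of the two numbers in this assay; compound 2 sits close by, with a gap that is within the usual scatter, so no order between the two is claimed. The third value is only a limit, (the limit of > 100000 nM in this assay, at which 1 of the 3 values shown sits).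

One measured step is shown: an at least 5.6-fold higher number from compound 2 to compound 3 (0.75 log units; beyond the scatter). That change sits at the other end of the shared core, on the chain carbon bound to the amide-type nitrogen, and says nothing about the acyl group on the aromatic amide nitrogen.

Compound 4, `COc1ccc(CNC(=O)CSc2nc3ccc(NC(=O)c4ccc(Cl)cc4)cc3s2)cc1`, differs from compound 1 as follows: 4-chlorophenyl in place of 2-methoxyphenyl on a carbonyl carbon. Among the compounds with values here, no measured pair varies that carbonyl substituent, so there is no step to read the size of the change from. With compound 1 at 9300 nM and no evidence for a shift in either direction, the expectation is a number in the same region, with wide uncertainty. Compound 4 is estimated at 9300 nM, between 3000 nM and 30000 nM, a step of no change at the digits printed from compound 1 to compound 4 (within the scatter) expected to stay within the scatter.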

Compound 4, half-maximal inhibitory concentration: 19200 nM
Compound 4: middle estimate off by 2.1-fold (0.31 log units), on the low side; the range from low to high includes it.
By their numbers in this assay, from the lowest: compounds 1, 2 and 4 (each within the scatter of the next, the first and the last beyond it). At a limit, above all of these: compound 3.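

Within the data shown here, the acyl group on the aromatic amide nitrogen, which no earlier pair varied, now has one measured change in this assay: a 2.1-fold higher number from compound 1 to compound 4 (0.31 log units; beyond the scatter). The carbonyl substituent therefore does shift the number in this series, though the step is modest and rests on a single pair, with 4-chlorophenyl and 2-methoxyphenyl differing in both the substituent and its place on the phenyl ring. Nothing measured here accounts for the step, so it stands as an observation without a cause.

The compounds shown leave open whether the step follows from the loss of the methoxy group, the arrival of the chlorine or the change of ring position, a question that 4-methoxyphenyl or 2-chlorophenyl on the same carbonyl carbon would separate. Also open, going by these compounds, is how far this position tolerates a different kind of group, such as an unsubstituted phenyl, a basic amine on the phenyl ring or a carboxylic acid, and whether any such change would carry the number in this assay clearly below that of compound 1 at 9300 nM.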